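From 5-methylfuran-2-yl to thiophen-2-yl in the series

The compounds below may be only part of what the source reports. "The series", "measured", "known", "first", "only" and "open" are said of these compounds alone.

Going by the values given here, in a functional assay on MCF7 cells (Homo sapiens) for antiproliferative activity, read by sulforhodamine B assay, with a stated time of 48 h (on this read-out lower numbers stand for stronger inhibition and higher numbers for weaker inhibition), compound 1 (`COc1ccc(/C=C/C(=O)c2ccccc2-c2ccc(F)cc2)cc1`) gives 670 nM and compound 2 (`Cc1ccc(/C=C/C(=O)c2ccccc2-c2ccc(F)cc2)o1`) gives 23000 nM, the higher of the two numbers so far. Compound 3 (`O=C(/C=C/c1cccs1)c1ccccc1-c1ccc(F)cc1`) carries thiophen-2-yl in place of 5-methylfuran-2-yl on a double-bonded chain carbon bound to a double-bonded chain carbon. Among the compounds with values here, only one measured step bears on this place, a 34-fold higher number from compound 1 to compound 2 (1.54 log units; beyond the scatter), which is large and beyond the scatter. Within the data shown here, that step replaces 4-methoxyphenyl, so no measured step exchanges one five-membered aromatic ring for another. A modest move to a lower number in this assay is expected, leaving compound 3 closer to compound 2 than to compound 1. The expected change is a 2.6-fold lower number from compound 2 to compound 3 (0.41 log units; beyond the scatter). Compound 3 is estimated at 9000 nM, with an expected range of 2000 nM to 30000 nM.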

Compound 3, half-maximal inhibitory concentration: 9500 nM
Beside the measured number, compound 3's estimate is 1.1-fold (0.02 log units) below it; the range from low to high includes it.
By their numbers in this assay, from the lowest: compound 1; then compound 3; then compound 2.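

In this assay, exchanging one five-membered aromatic ring for another at this place still shifts the read-out, with a 2.4-fold lower number from compound 2 to compound 3 (0.38 log units; beyond the scatter) as a modest step, so this position responds to more than the choice between a six-membered and a five-membered ring. That step swaps the ring hetero atom and removes the methyl together, and the two contributions cannot be separated. The thiophen-2-yl recovers only part of the loss, as a 14-fold higher number from compound 1 to compound 3 (1.15 log units; beyond the scatter) leaves both five-membered rings well on the weak side of the 4-methoxyphenyl of compound 1, and no data at hand explain either step.

Open, from the compounds shown here alone, is how furan-2-yl without the methyl or 5-methylthiophen-2-yl would stand, as either would separate the methyl from the ring hetero atom. Also open, going by these compounds, is whether a six-membered ring carrying an amine, such as 4-aminophenyl, would hold the level of compound 1.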